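Series notes: from compound 3 to compound 4

The source may hold more compounds than are shown below. What is called first, only, known or untested is meant among the compounds shown, and "the series" means these compounds.

Compound 3 `Cc1nc(-c2nn(Cc3ccccc3F)c3ncccc23)oc1CO` gives 900 nM in a functional assay (aorta) with Oryctolagus cuniculus as the target (on this read-out higher numbers stand for weaker inhibition and lower numbers for stronger inhibition), the lowest of the three measured numbers; compound 1 `OCc1ccc(-c2nn(Cc3cccc(F)c3)c3ccccc23)o1` gives 10000 nM and compound 2 `OCc1ccc(-c2nn(Cc3ccccn3)c3ccccc23)o1` gives 16000 nM, both beyond the scatter from compound 3. Among the measured compounds shown here, the only measured one-place step, a 1.6-fold higher number from compound 1 to compound 2 (0.20 log units; within the scatter), concerns the group on the saturated chain carbon bound to an aromatic nitrogen and stays within the scatter. Compound 4 `Fc1ccccc1Cn1nc(-c2nn[nH]n2)c2cccnc21` differs from compound 3 by 2H-tetrazol-5-yl in place of 5-(hydroxymethyl)-4-methyl-1,3-oxazol-2-yl on an aromatic carbon. For the measured compounds named here, no measured step touches this position, and the surrounding rings also differ between compound 3 and the other two, so neither size nor direction of the change in this assay can be read from the data. The expected step is a 2.8-fold higher number from compound 3 to compound 4 (0.44 log units; beyond the scatter). The estimate for compound 4 is 2500 nM, with a range from 500 nM to 12000 nM.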

Compound 4, half-maximal inhibitory concentration: 8600 nM
The estimate for compound 4 lay 3.4-fold (0.54 log units) below the measured number; the range from low to high includes it.
By their numbers in this assay, from the lowest: compound 3; then compounds 4, 1 and 2 (each within the scatter of the next).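

Swapping 5-(hydroxymethyl)-4-methyl-1,3-oxazol-2-yl for 2H-tetrazol-5-yl gives a 9.6-fold higher number from compound 3 to compound 4 (0.98 log units; beyond the scatter) in this assay, so the group on this aromatic carbon does affect the read-out, and this change weakens inhibition. Both groups count the same hydrogen-bond donors and acceptors, so those counts alone do not account for this pair. Nothing at hand speaks to the cause of the step.

Still open, as far as these compounds go, is whether a carboxylic acid on this aromatic carbon would read like 2H-tetrazol-5-yl. Also open, from the compounds shown here alone, is how much of the step depends on the hydroxymethyl group alone.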